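The source may report more compounds than this note shows. Statements on the series, on what has been measured and on what is new or still open speak of the compounds shown alone.

Measured compounds: compound 1 `CCOC(=O)c1c(C)nc(-c2ccc(C#N)cc2)n1OC` and compound 2 `CCOC(=O)c1c(C)nc(-c2cccc(C#N)c2)n1OCC(N)=O`. In a functional assay on a cell-free system (plasma, Oryctolagus cuniculus) for inhibition, with stated times of 5 min, 1 min and 6 min (on this read-out higher numbers stand for weaker inhibition and lower numbers for stronger inhibition), compound 1 gives 13400 nM. In this assay compound 2 gives > 30000 nM, which is a limit of the assay and not a number. Among the measured compounds shown here, compound 2 thus stands at the limit of > 30000 nM in this assay, at which 1 of the 2 values shown sits; of the two values shown, its value is the one that is only a limit, and the value of compound 1 is the one that is a number. For the measured compounds named here, no step between measured compounds that differ in one place is known here, so these two values show only that much.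

Compound 3 `CCOC(=O)c1c(C)nc(-c2cccc(C#N)c2)n1OCc1ccc([N+](=O)[O-])cc1` is not yet measured. It differs from compound 2 in one place: 4-nitrophenyl in place of carbamoyl on a saturated chain carbon bound to an oxygen on an aromatic ring. Going by the values given here, with compound 2 at a limit, this account has no measured step to lean on, and it expects no step in this assay in either direction beyond the scatter; the expected step is an at least 1.2-fold lower number from compound 2 to compound 3 (0.07 log units; that floor lies within the scatter). Compound 3 is therefore estimated at 25000 nM in this assay, with a range from 8000 nM to 80000 nM and a fair chance that only a limit is reported again.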

Compound 3, half-maximal inhibitory concentration: 8750 nM
The estimate for compound 3 lay 2.9-fold (0.46 log units) above the measured number; the measured number falls inside the stated range.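

In this assay, replacing carbamoyl with 4-nitrophenyl on a saturated chain carbon bound to an oxygen on an aromatic ring gives an at least 3.4-fold lower number from compound 2 to compound 3 (0.53 log units; beyond the scatter). Among the compounds shown here, this is the first step that can be read at this place, and it shows that the read-out responds to what is carried there, as compound 3 gives 8750 nM, a true number, although inhibition remains in the micromolar range. The step can be stated only as a bound, and its full size stays unknown, because compound 2 sits at a limit of the assay and not at a number: the limit of > 30000 nM in this assay, at which 1 of the 3 values shown sits.

The single change swaps a whole group, so the compounds shown cannot separate the contribution of the aromatic ring from that of the nitro group; a plain benzyl group or a 4-aminobenzyl group at this place would address that question. For the compounds shown here, how a carboxylic acid or a longer chain would read here also stays open, and compound 1 differs from compound 3 in more than one place, so it adds no step to this comparison.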